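A ring grows by one carbon at the central linker

A few compounds are considered here, and "the series" means these few. Any claim that something is new, unique, unknown or untested is made for them only; others in the source may bear on it.

Three compounds share a core in which a benzamide bearing a beta-alanine acid is joined, through a single saturated carbon, to an aryl group carrying a pyrazole. In a functional assay on cells for antagonist activity at Glucagon receptor (Homo sapiens), read by cAMP accumulation, in the presence of a further agent that is not named here (a higher number here means a weaker inhibitor, a lower number a stronger inhibitor), compound 1, `CCCC(Nc1ccc(-n2cc(C(F)(F)F)cn2)nc1)c1ccc(C(=O)NCCC(=O)O)cc1`, gives 1300 nM. Compound 2, `O=C(O)CCNC(=O)c1ccc(C(Oc2ccc(-n3cc(C(F)(F)F)cn3)cc2)C2CCC2)cc1`, gives 3000 nM in this assay. Compound 3, `CCCC(Oc1ccc(-n2cc(C#N)cn2)cc1)c1ccc(C(=O)NCCC(=O)O)cc1`, reaches only the limit of this assay, > 50000 nM, which is a boundary rather than a number; of the three values, one sits at this limit, (the limit of > 50000 nM in this assay, at which 1 of the 3 values shown sits). Among the two numbers, compound 2 stands at the higher one, and its gap to compound 1 lies beyond the usual scatter.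

Compound 4, `O=C(O)CCNC(=O)c1ccc(C(Oc2ccc(-n3cc(C(F)(F)F)cn3)cc2)C2CCCC2)cc1`, has not yet been measured. It differs from compound 2 in one place: cyclopentyl in place of cyclobutyl on a saturated chain carbon bound to an aromatic carbon and an oxygen on an aromatic ring. Within the data shown here, no measured pair shows this change, so the expectation rests on the structures alone. The step from compound 2 to compound 4 is expected to be a 2.0-fold lower number from compound 2 to compound 4 (0.30 log units; within the scatter), a modest move toward a lower number that may not clear the scatter. Compound 4 is therefore estimated to give 1500 nM in this assay, with a range from 400 nM to 6000 nM.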

Compound 4, antagonist equilibrium constant: 4000 nM
Compound 4: the middle estimate sits 2.7-fold (0.43 log units) below what was measured, and the stated range covers the measured number.
By their numbers in this assay, from the lowest: compound 1; then compounds 2 and 4 (each within the scatter of the next). At a limit, above all of these: compound 3.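

Among these compounds, this is the first measured pair at this position: cyclopentyl in place of cyclobutyl gives a 1.3-fold higher number from compound 2 to compound 4 (0.12 log units; within the scatter) in this assay. On a saturated chain carbon bound to an aromatic carbon and an oxygen on an aromatic ring, the four-membered and five-membered carbon rings therefore cannot be told apart by this read-out, and the extra ring carbon costs nothing that clears the scatter. Nothing measured in this set speaks to why the two rings read alike.

The compounds shown leave open whether a cyclohexyl ring, or an open chain such as isopropyl, would read the same way at this carbon. Going by these compounds, it also remains open whether a ring containing oxygen, such as tetrahydropyranyl, would fit this pattern.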